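The compounds below may be only part of what the source reports. "The series", "measured", "known", "first", "only" and "open" are said of these compounds alone.

Measured so far in an assay on isolated protein with Bile acid receptor (Homo sapiens) as the target; on this read-out higher numbers stand for an effect only at larger amounts of compound and lower numbers for an effect already at smaller amounts:
compound 1 `COC(=O)/C=C/c1cccc(N(Cc2ccc(-c3ccc(F)c(F)c3)cc2)C(=O)C2CCCCC2)c1`: 72 nM
compound 2 `COC(=O)/C=C/c1cccc(N(Cc2ccc(-c3c(OC)cccc3OC)cc2)C(=O)C(C)C)c1`: 95 nM

Compound 1 gives the lowest of the two numbers shown in this assay, but compound 2 stands close to it and the gap between the two lies within the usual scatter, so neither can be placed ahead of the other. Compound 3 `COC(=O)/C=C/c1cccc(N(Cc2ccc(/C=C/C(=O)N(C)C)cc2)C(=O)C2CCCCC2)c1` has not yet been measured in this assay. It differs from compound 1 in one place: 2-(dimethylcarbamoyl)ethenyl in place of 3,4-difluorophenyl on an aromatic carbon The group that leaves carries a six-membered aromatic ring of carbon only; the group that enters has no ring and carries 1 hydrogen-bond acceptor. Among the measured compounds shown here, no measured pair shows a change of this kind, so its effect in this assay cannot be read from the numbers at hand. A moderate shift toward a higher number is expected, a 2.2-fold higher number from compound 1 to compound 3 (0.35 log units; beyond the scatter). Compound 3 is therefore estimated at 160 nM, with a range from 50 nM to 500 nM.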

Compound 3, half-maximal effective concentration: > 1000 nM
Compound 3 gave a limit, no number (the forecaster's own chance of this, stated with the estimate: 5%); middle value at least 6.2-fold (0.79 log units) away from the limit.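

In this assay, the value of compound 3 is a limit of the assay, not a number: the limit of > 1000 nM in this assay, at which 1 of the 3 values shown sits. Even so, the position para to a large group proves sensitive to what it carries: 2-(dimethylcarbamoyl)ethenyl in place of 3,4-difluorophenyl gives an at least 13-fold higher number from compound 1 to compound 3 (1.14 log units; beyond the scatter), a step beyond the scatter. Similar size alone does not preserve the read-out here, since 7 heavy atoms without a ring replace 8 heavy atoms with a ring, and this is the first single-place comparison in the series.

Going by these compounds, the full size of the step stays unknown, and the data do not separate loss of the aromatic ring from the entry of the dimethylamide. An unsubstituted phenyl, a pyridine ring or a methyl ester on the same ethenyl link would be needed to tell these apart in this assay.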